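Aminobenzimidazole series: hydroxy in place of ethyl

The source may report more compounds than this note shows. Statements on the series, on what has been measured and on what is new or still open speak of the compounds shown alone.

Measured compounds in an assay on HEK293 cells for agonist activity at Toll-like receptor 8 (Homo sapiens), read by reporter gene assay; on this read-out lower numbers stand for an effect already at smaller amounts and higher numbers for an effect only at larger amounts of compound:
compound 1, `CCCCCn1c(N)nc2c(F)cccc21`: "not active" (no number reported)
compound 2, `CCCCCn1c(N)nc2c(CC)cccc21`: 1650 nM

Compound 1 gave no number in this assay and is reported only as inactive. Among the measured compounds shown here, compound 2 therefore stands as the only numerical value, with 1650 nM in this assay; no step between two measured values can be drawn, so the size of a change at this position has not yet been observed.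

Compound 3, `CCCCCn1c(N)nc2c(O)cccc21`, differs from compound 2 by hydroxy in place of ethyl on an aromatic carbon. With one inactive neighbour and one measured value on record, the direction is expected to be towards larger amounts of compound or none beyond the scatter, with wide uncertainty. The step from compound 2 to compound 3 is expected to be a 2.1-fold higher number from compound 2 to compound 3 (0.33 log units; beyond the scatter) in this assay. Compound 3 is estimated at 3500 nM, within 900 nM to 15000 nM.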

Compound 3, half-maximal effective concentration: 5010 nM
Estimate against measurement, compound 3: 1.4-fold (0.16 log units) below; the range from low to high includes it.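

In this assay, among the compounds shown here, the step of a 3.0-fold higher number from compound 2 to compound 3 (0.48 log units; beyond the scatter) is the first size of change on record at this aromatic carbon, for hydroxy in place of ethyl. A number is still reported with hydroxy here, while compound 1 with fluoro at the same carbon gives "not active" (no number reported) and has no value to compare, so a measurable read-out at this position does not require the ethyl group. No measurement at hand explains the difference between these compounds.

Going by these compounds, whether a methoxy group, an amine or a propyl chain on this carbon would read closer to compound 2 or to compound 3 remains open. Also open, on these data alone, is whether the same step would keep its size with a chain other than pentyl on the ring nitrogen of the shared core.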